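This account rests on a few compounds, and the source may have more. Where it says the series, first, only, none or still open, it means among the compounds named here.

Measured compounds:
- compound 1 `c1ccc(CSc2nnc(-c3ccc4c(c3)OCCO4)n2-c2ccccc2)cc1` gives 5960 nM in a functional assay on HepG2 cells (Homo sapiens) for antiproliferative activity, read by MTT assay, with a stated time of 24 h; on this read-out higher numbers stand for weaker inhibition and lower numbers for stronger inhibition.
- compound 2 `Fc1ccc(CSc2nnc(-c3ccc4c(c3)OCCO4)n2-c2ccccc2)c(F)c1` gives 1960 nM in this assay.

Compound 1 stands at the highest of the two numbers in this assay; its nearest neighbour is compound 2, and the step of a 3.0-fold lower number from compound 1 to compound 2 (0.48 log units; beyond the scatter) lies beyond the scatter. Compound 3 `Brc1cccc(CSc2nnc(-c3ccc4c(c3)OCCO4)n2-c2ccccc2)c1` has not yet been measured. It differs from compound 1 by bromo in place of hydrogen on an aromatic carbon. Among the compounds with values here, the only measured step that bears on this change is a 3.0-fold lower number from compound 1 to compound 2 (0.48 log units; beyond the scatter), in which 2,4-difluorophenyl took the place of phenyl on the saturated chain carbon bound to a sulfur; compound 3 instead carries one bromo on that ring, meta to a large group. A step in the same direction, a lowering of the number, but of smaller size is therefore expected in this assay. Compound 3 is estimated to give 3000 nM, within 1500 nM to 7000 nM. The step expected is a 2.0-fold lower number from compound 1 to compound 3 (0.30 log units; within the scatter).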

Compound 3, half-maximal inhibitory concentration: 5210 nM
The estimate for compound 3 lay 1.7-fold (0.24 log units) below the measured number, within the range that was stated.
By their numbers in this assay, from the lowest: compound 2; then compounds 3 and 1 (each within the scatter of the next).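

In this assay a single bromo on an aromatic carbon, meta to a large group, gives a 1.1-fold lower number from compound 1 to compound 3 (0.06 log units; within the scatter) and so leaves compound 3 indistinguishable from compound 1. The other comparison gives a 2.7-fold higher number from compound 2 to compound 3 (0.42 log units; beyond the scatter) and shows that the lower number of compound 2 does not carry over to every halogen-bearing ring in this series. No measurement given here accounts for this difference.

Compound 2 and compound 3 differ in the halogen, the number of halogens and their places on the ring, and these compounds cannot separate those three changes. From the compounds shown here alone, it also remains open how this position would respond to a single fluoro, or to an amine or a carboxylic acid in place of the bromo.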